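Swapping a Pyridine Ester for an Acetate

A few compounds are considered here, and "the series" means these few. Any claim that something is new, unique, unknown or untested is made for them only; others in the source may bear on it.

Measured in an ADME assay on HepG2 2.2.15 cells (Homo sapiens) for cytotoxicity, read by MTT assay; a lower number here means that less compound is tolerated, a higher number that more compound is tolerated:
- compound 1 `C=C1CC[C@@H]2[C@](C)(COC(=O)/C=C/c3cccc(Cl)c3)[C@H](O)CC[C@@]2(C)[C@@H]1/C=C/C1=CCOC1=O`: 147000 nM
- compound 2 `C=C1CC[C@@H]2[C@](C)(CO)[C@H](OC(=O)c3cccnc3)CC[C@@]2(C)[C@@H]1C/C=C1\C=COC1=O`: 337000 nM

Of these two compounds, compound 2 stands higher, at 337000 nM, and the gap to compound 1 lies beyond the scatter. The two differ in more than one place, so they do not isolate any single change. Compound 3 `C=C1CC[C@@H]2[C@](C)(CO)[C@H](OC(C)=O)CC[C@@]2(C)[C@@H]1C/C=C1\C=COC1=O` departs from compound 2 by methyl in place of pyridin-3-yl on a carbonyl carbon. Among the compounds with values here, no measured step shows what this change does, so no step beyond the scatter is expected in this assay. The expected step, a 1.2-fold lower number from compound 2 to compound 3 (0.08 log units; within the scatter), is estimated to stay within the scatter. For compound 3 the estimated value is 280000 nM, with an expected range of 110000 nM to 650000 nM.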

Compound 3, half-maximal cytotoxic concentration: 872000 nM
For compound 3 the middle estimate is 3.1-fold (0.49 log units) below the measured one, outside the stated range (above it).
By their numbers in this assay, from the lowest: compound 1; then compound 2; then compound 3.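

In this assay, within the data shown here, the change of methyl in place of pyridin-3-yl on a carbonyl carbon gives a 2.6-fold higher number from compound 2 to compound 3 (0.41 log units; beyond the scatter) and is the first change here confined to one place. It shows that the group on this carbonyl carbon alters how much compound is tolerated, with the acetyl ester tolerated at the higher concentration. No measurement here accounts for this step.

As far as these compounds go, whether a phenyl ring, which would separate the ring itself from its nitrogen, would behave like pyridin-3-yl or like methyl stays open. So does the outcome for a longer chain such as butyryl on this carbonyl carbon.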